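Fluoro in place of chloro: a step still unmeasured

The source may hold more compounds than are shown below. What is called first, only, known or untested is meant among the compounds shown, and "the series" means these compounds.

In a functional assay on DU-145 cells (Homo sapiens) for inhibition, read by CCK-8 assay, with a stated time of 72 h (on this read-out lower numbers stand for stronger inhibition and higher numbers for weaker inhibition), compound 1 `O=C(/C=C/c1cccnc1)NCCCCCCc1cccc(S(=O)(=O)Nc2ccccc2)c1` gives 6.73 nM, compound 2 `CC(C)(C)c1ccc(NS(=O)(=O)c2cccc(CCCCCCNC(=O)/C=C/c3cccnc3)c2)cc1` gives 281 nM, and compound 3 `O=C(/C=C/c1cccnc1)NCCCCCCc1cccc(S(=O)(=O)Nc2ccc(Cl)cc2)c1` gives 84.4 nM, the second highest of the three numbers. Compound 4 `O=C(/C=C/c1cccnc1)NCCCCCCc1cccc(S(=O)(=O)Nc2ccc(F)cc2)c1` differs from compound 3 by fluoro in place of chloro on an aromatic carbon, with fluoro in place of chloro on an aromatic carbon, para to a large group. Among the compounds with values here, no fluoro compound has been measured, so two steps offer the nearest guide: the large 13-fold higher number from compound 1 to compound 3 (1.10 log units; beyond the scatter) and the modest 3.3-fold lower number from compound 2 to compound 3 (0.52 log units; beyond the scatter). Fluoro is expected to land between hydrogen and chloro, which points to a modest move toward a lower number. The expected step is a 2.8-fold lower number from compound 3 to compound 4 (0.45 log units; beyond the scatter). For compound 4 the estimated value is 30 nM, with an expected range of 10 nM to 90 nM.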

Compound 4, half-maximal inhibitory concentration: 10.6 nM
Compound 4: the middle estimate sits 2.8-fold (0.45 log units) above what was measured, within the range that was stated.
By their numbers in this assay, from the lowest: compounds 1 and 4 (each within the scatter of the next); then compound 3; then compound 2.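

On this aromatic carbon, para to a large group, the choice of halogen counts: swapping chloro for fluoro gives an 8.0-fold lower number from compound 3 to compound 4 (0.90 log units; beyond the scatter) and swapping tert-butyl for fluoro gives a 27-fold lower number from compound 2 to compound 4 (1.42 log units; beyond the scatter) in the same direction. Fluoro is the one substituent shown that keeps pace with hydrogen, with a 1.6-fold higher number from compound 1 to compound 4 (0.20 log units; within the scatter) as the whole difference between them. Nothing measured here explains these gaps.

The compounds shown leave open whether a methoxy, methyl or trifluoromethyl group on this same carbon would stay with fluoro and hydrogen or fall with chloro and tert-butyl.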